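The source may report more compounds than this note shows. Statements on the series, on what has been measured and on what is new or still open speak of the compounds shown alone.

Of the compounds shown here, two have been tested so far in an ADME assay on microsomes from liver (Mus musculus) for metabolic stability, read by LC-MS, using NADPH, tested at 4.6 uM; on this read-out higher numbers stand for a longer-lived compound and lower numbers for a shorter-lived compound. Compound 1 `CCOCCNC(=O)n1cc(-c2ccccc2)oc1=O` gives < 0.0834 h, which is a limit of the assay and not a number. Going by the values given here, compound 2 `COc1cccc(-c2cn(C(=O)NCCCCc3ccccc3)c(=O)o2)c1` gives 0.5 h, the only actual number available, so it is the reference point here.

Compound 3 `O=C(NCCCCc1ccccc1)n1cc(-c2cnccn2)oc1=O` has not yet been measured. It keeps the rest of compound 2 but carries pyrazin-2-yl in place of 3-methoxyphenyl on an aromatic carbon.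

Among the compounds with values here, no two measured compounds differ in just one place, so nothing yet shows what a change like this does to the half-life. Within the data shown here, with compound 2 at 0.5 h as the only guide, the expected step of a 1.3-fold lower number from compound 2 to compound 3 (0.10 log units; within the scatter) is none beyond the usual scatter. The estimated half-life of compound 3 is 0.4 h, with an expected range from 0.12 h to 1.2 h.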

Compound 3, half-life: 1 h
For compound 3 the middle estimate is 2.5-fold (0.40 log units) below the measured one; low and high end bracket the measured number.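

In this assay, pyrazin-2-yl in place of 3-methoxyphenyl on this aromatic carbon, next to the ring oxygen, gives a 2.0-fold higher number from compound 2 to compound 3 (0.30 log units; within the scatter). At this position, then, a ring of carbon only and a ring with 2 hetero atoms can be exchanged without a difference in half-life that rises beyond the scatter, although this rests on a single pair. Compound 1 carries a limit of the assay and not a number, and it differs from the others in more than one place, so it adds nothing to this reading: the limit of < 0.0834 h in this assay, at which 1 of the 3 values shown sits.

Still open, on these data alone, is what other groups would do on this carbon, such as an amine or a carboxylic acid. Also open, as far as these compounds go, is whether the same exchange gives a similar step on a core with a different chain, such as the chain of compound 1.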